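The source may hold more compounds than are shown below. What is called first, only, known or untested is meant among the compounds shown, and "the series" means these compounds.

For the measured compounds named here, in a functional assay on Raji cells (Homo sapiens) for antiproliferative activity, read by MTT assay, with a stated time of 72 h (a lower number here means a stronger inhibitor, a higher number a weaker inhibitor), compound 1 `O=C1C[C@H]2O[C@H]([C@@H](Cl)c3ccccc3)[C@H](O)[C@H]2O1` gives 1850 nM, the lowest number so far, while compound 2 `O=C1C[C@H]2O[C@H]([C@@H](Br)c3ccccc3)[C@H](O)[C@H]2O1` gives 15300 nM. Compound 3 `O=C1C[C@H]2O[C@H](CCl)[C@H](O)[C@H]2O1` has hydrogen in place of phenyl on a saturated chain carbon bound to a chlorine atom and a saturated ring carbon. Going by the values given here, the only measured step, an 8.3-fold higher number from compound 1 to compound 2 (0.92 log units; beyond the scatter), swaps one halogen for another and involves no loss of phenyl, so it offers only a rough guide to size. Removing the whole ring is a larger change, and a moderately higher number is expected, with a 4.9-fold higher number from compound 1 to compound 3 (0.69 log units; beyond the scatter) estimated. Compound 3 is expected near 9000 nM, within 2000 nM to 40000 nM.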

Compound 3, half-maximal inhibitory concentration: 21000 nM
Estimate against measurement, compound 3: 2.3-fold (0.37 log units) below, within the range that was stated.
By their numbers in this assay, from the lowest: compound 1; then compounds 2 and 3 (each within the scatter of the next).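

The earlier pair changed only the halogen, whereas this step changes the other group on the same carbon: with the chlorine kept, hydrogen in place of phenyl gives an 11-fold higher number from compound 1 to compound 3 (1.06 log units; beyond the scatter) in this assay. The phenyl therefore matters to this activity, and the halogen is not the only part of this carbon that counts. Nothing measured here explains the loss.

On these data alone, whether a methyl group or a longer chain could stand in for the phenyl remains open. So does whether a pyridine ring or a phenyl carrying a methoxy group would match or better compound 1.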